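From furan-2-yl to thiophen-2-yl at the assay limit

The source may report more compounds than this note shows. Statements on the series, on what has been measured and on what is new or still open speak of the compounds shown alone.

Measured so far in a functional assay on SNB-19 cells (Homo sapiens) for inhibition, read by MTT assay, with a stated time of 7 days (on this read-out higher numbers stand for weaker inhibition of growth and lower numbers for stronger inhibition of growth), are three compounds:
- compound 1 `CC(c1ccc(Br)cc1)n1nnc2c(C(N)=O)ncn2c1=O` gives > 50000 nM as a limit
- compound 2 `NC(=O)c1nc[nH]c1N/N=N/Cc1ccccc1` gives > 50000 nM as a limit
- compound 3 `NC(=O)c1nc[nH]c1N/N=N/Cc1ccco1` gives > 50000 nM as a limit

Compound 3 stands at > 50000 nM as a limit and not a number. For the measured compounds named here, its two companions give no number either: compound 1, compound 2 and compound 3 share the limit of > 50000 nM in this assay, at which 3 of the 3 values shown sit, as their only reading.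

The change to compound 4 `NC(=O)c1nc[nH]c1N/N=N/Cc1cccs1` is thiophen-2-yl in place of furan-2-yl on a saturated chain carbon bound to a double-bonded nitrogen, counted as thiophen-2-yl in place of furan-2-yl on a saturated chain carbon bound to a double-bonded nitrogen in full.

Going by the values given here, the one measured step at this same place is a step that the two limits leave unreadable from compound 2 to compound 3 and it offers no size to carry over. Nothing measured therefore points to a gain or a loss from the new group, so no step beyond the usual scatter is expected in this assay and no direction can be named. The most likely outcome is that this measurement again returns only a limit. The expected change is a number no higher from compound 3 to compound 4 (the limit leaves the size open) as estimated here. For compound 4 the estimate is 50000 nM with an expected range from 25000 nM to 100000 nM for the measurement.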

Compound 4, concentration for 50% growth inhibition: > 50000 nM
Compound 4: a limit, no number; the forecaster's own chance of this, stated with the estimate: 85%; the middle value sits exactly at the limit.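

In this assay compound 4 gives > 50000 nM, a limit and not a number. No new step can be read among compound 2, compound 3 and compound 4 because each gives only a limit: the limit of > 50000 nM in this assay, at which 4 of the 4 values shown sit.

The compounds shown leave open whether phenyl, furan-2-yl and thiophen-2-yl differ at all in their inhibition of growth.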